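Trimming the 3-hydroxypropyl chain to propyl

The source may hold more compounds than are shown below. What is called first, only, known or untested is meant among the compounds shown, and "the series" means these compounds.

Compound 1 `COc1ccc(C[C@H]2C(=O)N[C@@H](C)C(=O)N(C)[C@H]3Cc4ccc(cc4)Oc4cc(ccc4OC)C[C@@H](C(=O)N[C@H](C)C(=O)NC4(SCCS4)C(=O)N2C)N(C)C3=O)cc1`: 631 nM
Compound 2 `COc1ccc(C[C@H]2C(=O)N[C@@H](C)C(=O)N(C)[C@H]3Cc4ccc(cc4)Oc4cc(ccc4OC)C[C@@H](C(=O)N[C@H](C)C(=O)N[C@@H](CCCO)C(=O)N2C)N(C)C3=O)cc1`: 174 nM
Compound 3 `COc1ccc(C[C@H]2C(=O)N[C@@H](C)C(=O)N(C)[C@H]3Cc4ccc(cc4)Oc4cc(ccc4OC)C[C@@H](C(=O)N[C@H](C)C(=O)N[C@@H](CCCCO)C(=O)N2C)N(C)C3=O)cc1`: 219 nM

All three numbers come from a functional assay on P388 cells (Mus musculus) for cytotoxicity (a lower number here means a stronger inhibitor, a higher number a weaker inhibitor), and the compounds share one core. Compound 2 and compound 3 lie within the usual scatter of each other, so they cannot be told apart here. Compound 1 shows a higher number than compound 2, and that gap is beyond the scatter.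

Compound 4 `CCC[C@@H]1NC(=O)[C@@H](C)NC(=O)[C@@H]2Cc3ccc(OC)c(c3)Oc3ccc(cc3)C[C@@H](C(=O)N2C)N(C)C(=O)[C@H](C)NC(=O)[C@H](Cc2ccc(OC)cc2)N(C)C1=O` has not yet been measured. It differs from compound 2 at a single place hydrogen in place of hydroxy on a saturated chain carbon, three bonds along the chain from a saturated ring carbon and so carries propyl where compound 2 carries 3-hydroxypropyl.

Among the measured compounds shown here, the one measured step at this place is a 1.3-fold higher number from compound 2 to compound 3 (0.10 log units; within the scatter) and it swaps hydroxymethyl in for hydroxy. That step stays within the scatter, but compound 3 still has a hydroxy group on its chain. For the measured compounds named here, compound 4 has none, and no measured compound here tests that loss directly.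

The measured step therefore gives no reason to expect a clear move in either direction in this assay beyond the scatter. The expected change is a 1.1-fold lower number from compound 2 to compound 4 (0.04 log units; within the scatter) as a rough estimate. For compound 4 the expected value is 160 nM with an estimated range from 55 nM to 470 nM as the likely span.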

Compound 4, half-maximal inhibitory concentration: 13.8 nM
Compound 4: middle estimate off by 12-fold (1.06 log units), on the high side; measured number below the stated range.
By their numbers in this assay, from the lowest: compound 4; then compounds 2 and 3 (each within the scatter of the next); then compound 1.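

In this assay, putting hydrogen in place of hydroxy gives a 13-fold lower number from compound 2 to compound 4 (1.10 log units; beyond the scatter), and putting hydrogen in place of hydroxymethyl gives a 16-fold lower number from compound 3 to compound 4 (1.20 log units; beyond the scatter). Both steps are large and beyond the scatter, whereas the earlier step between the two hydroxy-bearing chains, a 1.3-fold higher number from compound 2 to compound 3 (0.10 log units; within the scatter), stayed within it, so at this position the presence or absence of the hydroxy group separates these three compounds far more clearly than the swap between compound 2 and compound 3 did. No separate measurement accounts for this large drop in the number.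

The compounds shown leave open whether the low number belongs to propyl specifically or would also appear with ethyl or with a longer chain such as butyl. They also leave open what a methoxy group, an amine or a carboxylic acid would do in place of the hydroxy, which would show whether the effect of the hydroxy is particular to that group or is shared by other groups at this position.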